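A few compounds are considered here, and "the series" means these few. Any claim that something is new, unique, unknown or untested is made for them only; others in the source may bear on it.

Of the compounds shown here, three from one series have been tested in an ADME assay on MT4 cells (Homo sapiens) for cytotoxicity, read by MTT assay; a higher number here means that more compound is tolerated, a lower number that less compound is tolerated. Compound 1 has the structure `O=C(CSc1nc(Cc2c(F)cccc2Cl)cc(=O)[nH]1)c1ccc(F)cc1`. In this assay compound 1 reaches only a limit of the assay, > 61000 nM. Compound 2, with the structure `COc1ccc(C(=O)CSc2nc(Cc3c(F)cccc3Cl)cc(=O)[nH]2)cc1`, differs from compound 1 by methoxy in place of fluoro on an aromatic carbon. In this assay compound 2 likewise gives only a limit, > 12000 nM. The step that the two limits leave unreadable from compound 1 to compound 2 cannot be sized because the limit of > 61000 nM in this assay, at which 1 of the 3 values shown sits, and the limit of > 12000 nM in this assay, at which 1 of the 3 values shown sits, are both limits rather than numbers.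

Compound 3 has the structure `CCc1c(Cc2c(F)cccc2F)nc(SCC(=O)c2ccc(F)cc2)[nH]c1=O`. The difference between its core and the core of compound 1 is not broken down here. In this assay compound 3 again gives only a limit, > 60000 nM, and this is where the limit of > 60000 nM in this assay, at which 1 of the 3 values shown sits, sits.

Compound 4, with the structure `CCc1c(Cc2c(F)cccc2F)nc(SCC(=O)c2ccc(OC)cc2)[nH]c1=O`, has not yet been measured. Among the compounds with values here, it differs from compound 3 by methoxy in place of fluoro on an aromatic carbon, which is the same change as the one from compound 1 to compound 2, made here on the core of compound 3. For compound 4 the expected step is a number no higher from compound 3 to compound 4 (the limit leaves the size open). This expectation rests on the step that the two limits leave unreadable from compound 1 to compound 2, which two limits left unreadable, so that nothing shows the change bringing the tolerated concentration down into the readable range. Compound 4 is therefore estimated at 60000 nM, between 12000 nM and 120000 nM, and most likely reported again as a limit.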

Compound 4, half-maximal cytotoxic concentration: > 58000 nM
Compound 4: a limit, no number; the forecaster's own chance of this, stated with the estimate: 80%; the middle value does not contradict the limit.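

In this assay, compound 3 and compound 4 both give only limits of the assay, not numbers, so the step from fluoro to methoxy between them cannot be read. The compounds shown leave open at what concentration any of the four becomes toxic to the cells, and whether methoxy in place of fluoro changes that concentration on either core.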